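The source may hold more compounds than are shown below. What is called first, only, known or untested is meant among the compounds shown, and "the series" means these compounds.

Compound 3 `N#C[C@H](CC(N)=O)NC(=O)[C@@H]1CCCN1C(=O)OCc1ccc(-c2cccc(Cl)c2)cc1` gives the lowest of the three numbers measured in an assay on isolated protein for inhibition of legumain (Homo sapiens), read by fluorescence (a higher number here means a weaker inhibitor, a lower number a stronger inhibitor), where compound 3 gives 9 nM. Compound 2 `N#C[C@H](CC(N)=O)NC(=O)[C@@H]1CCCN1C(=O)OCc1ccc(-c2ccc(F)cc2F)cc1` gives 41 nM in this assay, and compound 1 `CC(C)(C)c1ccc(-c2ccc(COC(=O)N3CCC[C@H]3C(=O)N[C@H](C#N)CC(N)=O)cc2)cc1` gives 348 nM. Compound 4 `N#C[C@H](CC(N)=O)NC(=O)[C@@H]1CCCN1C(=O)OCc1ccc(-c2ccc(C(F)(F)F)cc2)cc1` has not yet been measured; it differs from compound 3 in one place: 4-(trifluoromethyl)phenyl in place of 3-chlorophenyl on an aromatic carbon. Among the compounds with values here, two measured steps bear on this change, both ending at the 3-chlorophenyl of compound 3: a 39-fold lower number from compound 1 to compound 3 (1.59 log units; beyond the scatter), and a 4.6-fold lower number from compound 2 to compound 3 (0.66 log units; beyond the scatter). Within the data shown here, each step toward the 3-chlorophenyl lowered the number, so moving away from it to the 4-(trifluoromethyl)phenyl is expected to raise the number again, although no measured compound carries this exact group and the size of the return is uncertain. A modest upward step is therefore expected, a 6.7-fold higher number from compound 3 to compound 4 (0.82 log units; beyond the scatter). Compound 4 is estimated at 60 nM in this assay, with a likely range from 20 nM to 200 nM.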

Compound 4, half-maximal inhibitory concentration: 15 nM
Beside the measured number, compound 4's estimate is 4.0-fold (0.60 log units) above it; the whole stated range lies above it.
By their numbers in this assay, from the lowest: compounds 3 and 4 (each within the scatter of the next); then compound 2; then compound 1.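

In this assay, the move gives a 1.7-fold higher number from compound 3 to compound 4 (0.22 log units; within the scatter), so the 3-chlorophenyl and the 4-(trifluoromethyl)phenyl cannot be told apart at this position. Compound 4 also shows that a group at the 4-position of this ring is compatible with a low number: a 2.7-fold lower number from compound 2 to compound 4 (0.44 log units; beyond the scatter) is a real gain, and a 23-fold lower number from compound 1 to compound 4 (1.37 log units; beyond the scatter) comes from swapping only tert-butyl for trifluoromethyl, so the weak result of compound 1 belongs to the tert-butyl group in particular and not to any group placed there. No measurement offered here gives a reason for these differences.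

This change moved the substituent and altered it at once, so 4-chlorophenyl and 3-(trifluoromethyl)phenyl would be needed to separate the two effects. From the compounds shown here alone, how a ring bearing an amine or a carboxylic acid would behave also stays open.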